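The compounds below may be only part of what the source reports. "The series", "measured", "known", "first", "only" and "open" are said of these compounds alone.

Working notes on the series. In a functional assay on A549 cells (Homo sapiens) for cytotoxicity, read by MTT assay, with a stated time of 72 h (on this read-out higher numbers stand for weaker inhibition and lower numbers for stronger inhibition), compound 1 (`CNC(=O)c1cc(Oc2ccc(C3=NNC(c4cc(OC)c(OC)c(OC)c4)C3)cc2)ccn1`) gives 37100 nM, compound 3 (`CNC(=O)c1cc(Oc2ccc(C3=NNC(c4ccc(OC)c(OC)c4OC)C3)cc2)ccn1`) gives 19000 nM and compound 2 (`CNC(=O)c1cc(Oc2ccc(C3=NNC(c4ccc(OC)cc4)C3)cc2)ccn1`) gives 13100 nM. Compound 2 and compound 3 lie within the scatter of each other, while compound 2 has a lower number than compound 1, by a gap beyond the scatter. Compound 4 (`CNC(=O)c1cc(Oc2ccc(C3=NNC(c4cccc(Cl)c4Cl)C3)cc2)ccn1`) has 2,3-dichlorophenyl in place of 4-methoxyphenyl on a saturated ring carbon. Going by the values given here, no measured pair differs in one place only, so the data do not show the size of such a step. No step beyond the scatter is expected in this assay. The estimate amounts to an expected step of a 1.2-fold lower number from compound 2 to compound 4 (0.08 log units; within the scatter). For compound 4 the estimated value is 11000 nM, with an expected range of 4000 nM to 30000 nM.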

Compound 4, half-maximal inhibitory concentration: 12100 nM
Compound 4: middle estimate off by 1.1-fold (0.04 log units), on the low side; measured number inside the range.
By their numbers in this assay, from the lowest: compounds 4, 2, 3 and 1 (each within the scatter of the next, the first and the last beyond it).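

Going by these compounds alone, on the saturated ring carbon, 2,3-dichlorophenyl in place of 4-methoxyphenyl gives the first step in this assay that can be read from a single change, a 1.1-fold lower number from compound 2 to compound 4 (0.03 log units; within the scatter), so the two aryl groups cannot be told apart at this position. The methoxy group of compound 2 is thus not needed to keep the number in this range, at least when the two chlorines of compound 4 take its place. Nothing measured here gives a reason for this result. Still open, going by these compounds, is whether an amine, a carboxylic acid or a longer chain on this carbon would stay within the scatter of compound 2. Also open, on these data alone, is how a phenyl with a single chlorine would compare.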